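Replacing Butylsulfanyl with 3-Chloro-4-fluorophenyl

The source may report more compounds than this note shows. Statements on the series, on what has been measured and on what is new or still open speak of the compounds shown alone.

Compound 1 `Cc1ccc(N2CCN(c3cc(C(F)(F)F)ccc3CNC(=O)C(C)c3ccc(NS(C)(=O)=O)c(F)c3)CC2)cc1`: in an assay on CHO cells for antagonist activity at transient receptor potential cation channel subfamily V member 1 (Homo sapiens), read by FLIPR (a lower number here means a stronger inhibitor, a higher number a weaker inhibitor), compound 1 gives 0.7 nM.
Compound 2 `COc1ccc(N2CCN(c3cc(C(F)(F)F)ccc3CNC(=O)C(C)c3ccc(NS(C)(=O)=O)c(F)c3)CC2)cc1`: compound 2 gives 1.6 nM.
Compound 3 `CCCCSc1cc(C(F)(F)F)ccc1CNC(=O)C(C)c1ccc(NS(C)(=O)=O)c(F)c1`: compound 3 gives 1.9 nM.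

Compound 3 has the highest number of the three; its gap to compound 2 is within the scatter, its gap to compound 1 beyond it. Compound 4 `CC(C(=O)NCc1ccc(C(F)(F)F)cc1-c1ccc(F)c(Cl)c1)c1ccc(NS(C)(=O)=O)c(F)c1` differs from compound 3 by 3-chloro-4-fluorophenyl in place of butylsulfanyl on an aromatic carbon. Going by the values given here, the only measured step, a 2.3-fold higher number from compound 1 to compound 2 (0.36 log units; beyond the scatter), concerns another position and another kind of change, so no measured step bears directly on this one. Because compound 1 gives 0.7 nM and compound 3 gives 1.9 nM with quite different groups at this position, compound 4 is expected to remain close to compound 3, with a 1.6-fold higher number from compound 3 to compound 4 (0.20 log units; within the scatter) at most a small step toward a higher number. Compound 4 is estimated at 3 nM, within 0.8 nM to 12 nM.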

Compound 4, inhibition constant: 0.6 nM
For compound 4 the middle estimate is 5.0-fold (0.70 log units) above the measured one; measured number below the stated range.
By their numbers in this assay, from the lowest: compounds 4 and 1 (each within the scatter of the next); then compounds 2 and 3 (each within the scatter of the next).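

In this assay the exchange of butylsulfanyl for 3-chloro-4-fluorophenyl gives a 3.2-fold lower number from compound 3 to compound 4 (0.50 log units; beyond the scatter), a modest step beyond the scatter. This position, ortho to a large group, therefore accepts a six-membered aromatic ring of carbon only in place of an open chain, and the number falls rather than rises. Nothing available gives a cause for this fall.

From the compounds shown here alone, it remains open how much of the step belongs to the ring itself and how much to its chlorine and fluorine, which a plain phenyl group at this position would separate. A butoxy chain would likewise show whether the sulfur of butylsulfanyl matters.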